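ROCK1 series: extending the amide-nitrogen substituent

The source may hold more compounds than are shown below. What is called first, only, known or untested is meant among the compounds shown, and "the series" means these compounds.

Measured compounds:
compound 1, `CC1(C)NC(=O)c2sc(-c3ccncc3)cc2N1`: 90 nM
compound 2, `CCC1(C)NC(=O)c2sc(-c3ccncc3)cc2N1`: 36 nM
compound 3, `CN1C(=O)c2sc(-c3ccncc3)cc2NC1(C)C`: 240 nM

In an assay for inhibition of Rho-associated protein kinase 1 (Homo sapiens), read by TR-FRET, with stated times of 5 min and 2 h (on this read-out lower numbers stand for stronger inhibition and higher numbers for weaker inhibition), compound 3 gives 240 nM, the highest number of the three; it sits a 2.7-fold higher number from compound 1 to compound 3 (0.43 log units; beyond the scatter), and compound 2 is further still. The next compound, compound 4, `CC1(C)Nc2cc(-c3ccncc3)sc2C(=O)N1Cc1ccccc1`, differs from compound 3 by phenyl in place of hydrogen on a saturated chain carbon bound to an amide-type nitrogen in a ring. Among the measured compounds shown here, no measured step alters the substituent on the amide-type nitrogen beyond the first carbon, so the bearing of the known steps is indirect. The step of a 2.7-fold higher number from compound 1 to compound 3 (0.43 log units; beyond the scatter) shows that placing a methyl on that nitrogen costs potency, and a 2.5-fold lower number from compound 1 to compound 2 (0.40 log units; beyond the scatter) shows that more carbon on the saturated ring carbon of the core helps; neither tells what a larger group on the nitrogen does. The direction is therefore uncertain: a further rise in number is taken as the more likely outcome, with a wide range. Compound 4 is estimated at 400 nM (range 120 nM to 1500 nM), which would correspond to a 1.7-fold higher number from compound 3 to compound 4 (0.22 log units; within the scatter).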

Compound 4, half-maximal inhibitory concentration: 1.5 nM
Compound 4: the middle estimate sits 270-fold (2.43 log units) above what was measured; the measured number lies below the stated range.
By their numbers in this assay, from the lowest: compound 4; then compound 2; then compound 1; then compound 3.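

In this assay the amide-type nitrogen of the shared core proves far more responsive than compound 3 alone indicated, with a 160-fold lower number from compound 3 to compound 4 (2.20 log units; beyond the scatter) on placing phenyl on the saturated chain carbon bound to that nitrogen. Measured against the unsubstituted nitrogen, benzyl gives a 60-fold lower number from compound 1 to compound 4 (1.78 log units; beyond the scatter) and so reverses the loss seen with methyl, which means that the cost of methyl does not extend to every substituent at this nitrogen. No evidence at hand accounts for this gain.

Still open, on these data alone, is whether the gain requires the phenyl ring, since a cyclohexylmethyl group or a longer alkyl chain on the same nitrogen would separate the ring from the added carbon. Also open, as far as these compounds go, is how far the ring accepts substitution, for example by an amine or a carboxylic acid.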